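Hydrazone aryl swap in the pyrazole carbohydrazide series

The compounds below may be only part of what the source reports. "The series", "measured", "known", "first", "only" and "open" are said of these compounds alone.

Measured so far:
Compound 1 `O=C(N/N=C/c1cccc(O)c1O)c1cc(-c2ccc(Cl)cc2)nn1Cc1ccc(Cl)nc1`: 570 nM
Compound 2 `CC(C)(C)c1ccc(Cn2nc(-c3ccc(Cl)cc3)cc2C(=O)N/N=C/c2ccc(F)cc2F)cc1`: 21900 nM

In a functional assay on NCI-H23 cells (Homo sapiens) for antiproliferative activity, read by BrdU incorporation, with a stated time of 48 h (on this read-out higher numbers stand for weaker inhibition and lower numbers for stronger inhibition), compound 2 gives 21900 nM, the higher of the two numbers recorded; in this assay compound 1 gives 570 nM, a much lower number, and the gap between the two is beyond the scatter. Compound 1 and compound 2 differ at two places, so the two values say nothing on their own about either change.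

Compound 3 `CC(C)(C)c1ccc(Cn2nc(-c3ccc(Cl)cc3)cc2C(=O)N/N=C/c2cccc(O)c2O)cc1` keeps the benzyl substituent of compound 2 and carries the change (2,3-dihydroxyphenyl in place of 2,4-difluorophenyl on a carbon with a double bond to nitrogen). Going by the values given here, the entering group is the one present in compound 1, which gives 570 nM in this assay. On that basis a large step down in number is expected, a 15-fold lower number from compound 2 to compound 3 (1.16 log units; beyond the scatter), since compound 1 with the same group sits far lower than compound 2, though the benzyl substituent also differs, so the size of the step is uncertain. Compound 3 is estimated at 1500 nM in this assay, within 300 nM to 8000 nM.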

Compound 3, half-maximal inhibitory concentration: 300 nM
Compound 3: the middle estimate sits 5.0-fold (0.70 log units) above what was measured; measured number inside the range.
By their numbers in this assay, from the lowest: compounds 3 and 1 (each within the scatter of the next); then compound 2.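

On the carbon with a double bond to nitrogen, 2,3-dihydroxyphenyl in place of 2,4-difluorophenyl gives a 73-fold lower number from compound 2 to compound 3 (1.86 log units; beyond the scatter) in this assay and so isolates an aryl effect that the first two compounds could not assign. With 2,3-dihydroxyphenyl held constant, 4-(tert-butyl)phenyl in place of 6-chloropyridin-3-yl on a saturated chain carbon bound to an aromatic nitrogen gives a 1.9-fold lower number from compound 1 to compound 3 (0.28 log units; within the scatter) and leaves the two substituents unseparated in this assay for now. No supporting data bear on why the aryl change matters so much.

Open, from the compounds shown here alone, is whether both hydroxyl groups are needed, or whether a phenyl with a single hydroxyl or with two methoxy groups would read the same. Also open, going by these compounds, is whether the two benzyl substituents would remain indistinguishable with 2,4-difluorophenyl on the hydrazone.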